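The source may report more compounds than this note shows. Statements on the series, on what has been measured and on what is new or still open speak of the compounds shown alone.

For the measured compounds named here, compound 3 `COC(=O)/C=C/c1cccc(N(Cc2ccc(/C=C/c3ccc(OC)cc3)cc2)C(=O)C2CCCCC2)c1` has the highest of the two numbers measured so far in an assay on isolated protein with Bile acid receptor (Homo sapiens) as the target (on this read-out lower numbers stand for an effect already at smaller amounts and higher numbers for an effect only at larger amounts of compound), where compound 3 gives 208 nM. Compound 1 `COC(=O)/C=C/c1cccc(N(Cc2ccc(-c3cccc(C)c3)cc2)C(=O)C2CCCCC2)c1` sits nearest, with 109 nM in this assay; the step of a 1.9-fold higher number from compound 1 to compound 3 (0.28 log units; within the scatter). Compound 2 `CCOC(=O)/C=C/c1ccc(CN(C(=O)C2CCCCC2)c2cccc(/C=C/C(=O)OC)c2)cc1` reaches only the limit of this assay, > 1000 nM. The step of an at least 4.8-fold lower number from compound 2 to compound 3 (0.68 log units; beyond the scatter), and the step of an at least 9.1-fold higher number from compound 1 to compound 2 (0.96 log units; beyond the scatter). Compound 4 `COC(=O)/C=C/c1cccc(N(Cc2ccc(-c3cccc(OC(F)(F)F)c3)cc2)C(=O)C2CCCCC2)c1` differs from compound 3 in one place: 3-(trifluoromethoxy)phenyl in place of 2-(4-methoxyphenyl)ethenyl on an aromatic carbon. This largely undoes the change from compound 1 to compound 3, which stayed within the scatter, so the step of a 1.6-fold lower number from compound 3 to compound 4 (0.20 log units; within the scatter) is expected to be small. For compound 4 the estimate in this assay is 130 nM, with a likely range from 50 nM to 400 nM.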

Compound 4, half-maximal effective concentration: 420 nM
Compound 4: middle estimate off by 3.2-fold (0.51 log units), on the low side, outside the stated range (above it).
By their numbers in this assay, from the lowest: compounds 1 and 3 (each within the scatter of the next); then compound 4. At a limit, above all of these: compound 2.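

In this assay, keeping the phenyl and changing only methyl to trifluoromethoxy gives a 3.9-fold higher number from compound 1 to compound 4 (0.59 log units; beyond the scatter), so this position responds to a change on that phenyl alone. Swapping 2-(4-methoxyphenyl)ethenyl for 3-(trifluoromethoxy)phenyl gives a 2.0-fold higher number from compound 3 to compound 4 (0.31 log units; beyond the scatter), a modest step between two groups of similar heavy-atom count. Replacing 2-(ethoxycarbonyl)ethenyl gives an at least 2.3-fold lower number from compound 2 to compound 4 (0.37 log units; beyond the scatter), a step that rests on a limit rather than a number: the limit of > 1000 nM in this assay, at which 1 of the 4 values shown sits.

As far as these compounds go, it remains open how a chlorine or a hydroxyl group in place of methyl would fare. From the compounds shown here alone, whether an amine or a carboxylic acid on that phenyl would shift the number is also open.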